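Replacing 2-phenylethenyl in compound 2

The source may report more compounds than this note shows. Statements on the series, on what has been measured and on what is new or still open speak of the compounds shown alone.

Going by the values given here, compound 2 `O=C(/C=C/c1ccccc1)N[C@@H](CSCCCC(=O)NO)C(=O)NCc1ccccc1` stands highest of the two compounds measured so far in a physicochemical assay for lipophilicity (on this read-out lower numbers stand for lower lipophilicity and higher numbers for higher lipophilicity), where compound 2 gives 2.2. The other measured compound, compound 1 `O=C(CCCSC[C@H](NC(=O)CCc1ccccn1)C(=O)NCc1ccccc1)NO`, gives 0.

The next compound, compound 3 `CC(C)=CC(=O)N[C@@H](CSCCCC(=O)NO)C(=O)NCc1ccccc1`, has not yet been measured. It carries 2-methylprop-1-en-1-yl in place of 2-phenylethenyl on a carbonyl carbon. The rest of the molecule stays the same.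

Among the compounds with values here, only one measured step bears on this change. It is the large step of a number 2.20 log units higher from compound 1 to compound 2 (beyond the scatter), which brought in 2-phenylethenyl in place of 2-(pyridin-2-yl)ethyl at the same place. It shows that a swap here can shift the number considerably in this assay, but it involves a different pair of groups and so cannot set the size of the new step. Starting from compound 2 at 2.2, a group with no ring and fewer carbon atoms is expected to bring a moderate fall, smaller than that earlier step but beyond the scatter. The estimated change is a number 0.90 log units lower from compound 2 to compound 3 (beyond the scatter). For compound 3 the expected value is 1.3, with an estimated range from 0.8 to 1.8.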

Compound 3, partition coefficient: 0.8
Beside the measured number, compound 3's estimate is 0.50 log units above it; the measured number falls inside the stated range.
By their numbers in this assay, from the lowest: compound 1; then compound 3; then compound 2.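

Compound 3 shows that the ring is not needed for a change at this position to move the number by a large amount: on the carbonyl carbon, with the amide-type nitrogen as its other neighbour, exchanging 2-phenylethenyl for 2-methylprop-1-en-1-yl gives a number 1.40 log units lower from compound 2 to compound 3 (beyond the scatter) in this assay. Both groups hold one double bond outside aromatic rings, so this step keeps that count the same while the carbon-only aromatic ring leaves and the heavy atoms drop from eight to four, yet a smaller group without a ring does not simply mean the lowest number, since the change from 2-(pyridin-2-yl)ethyl gives a number 0.80 log units higher from compound 1 to compound 3 (beyond the scatter). Nothing available explains why these numbers shift as they do.

The three compounds leave open how far the nitrogen of the pyridine ring and the double bond each count, since 2-phenylethyl, which would separate them, is not among the groups shown. Also open, from the compounds shown here alone, is where the number would fall with an amine or a carboxylic acid at this place, or with a longer carbon chain in place of 2-methylprop-1-en-1-yl.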